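The compounds below may be only part of what the source reports. "The series", "measured", "known", "first", "only" and "open" are said of these compounds alone.

Compound 1 `COc1c(Br)cccc1C(=O)Nc1ccccc1` in an ADME assay on HEK293 cells (Homo sapiens) for cytotoxicity, read by reporter gene assay and resazurin assay, with a stated time of 48 h (on this read-out lower numbers stand for higher toxicity in this test and higher numbers for lower toxicity in this test), gives > 100000 nM, a limit of the assay rather than a number.
Compound 2 `O=C(Nc1ccccc1)c1cccc(Br)c1` in this assay gives > 100000 nM, again a limit.
Compound 3 `COc1ccccc1C(=O)Nc1ccc(Sc2nc3ccccc3s2)cc1` in this assay gives > 100000 nM, also a limit.

The change from compound 1 to compound 2 is hydrogen in place of methoxy on an aromatic carbon. Its step that the two limits leave unreadable from compound 1 to compound 2 cannot be sized because the limit of > 100000 nM in this assay, at which 3 of the 3 values shown sit, hides where either compound truly lies. Compound 4 `O=C(Nc1ccc(Sc2nc3ccccc3s2)cc1)c1ccccc1` is still unmeasured and differs from compound 3 by hydrogen in place of methoxy on an aromatic carbon, the same kind of change, though here the place is ortho to a large group, whereas in compound 1 it was ortho to a bromo group and ortho to a group of 9 heavy atoms. How the core of compound 3 differs from that of compound 1 is not broken down here.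

Since compound 3 gives > 100000 nM, a limit, compound 4 is expected to show a step that the limit leaves unreadable from compound 3 to compound 4 in this assay. Compound 4 is therefore estimated to sit near 150000 nM, most likely again reported only as a limit.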

Compound 4, half-maximal cytotoxic concentration: > 100000 nM
Compound 4 was reported as a limit; the forecaster's own chance of this, stated with the estimate: 85%; the middle value does not contradict the limit.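

No step can be read from compound 3 to compound 4, because both are reported only as limits: the limit of > 100000 nM in this assay, at which 4 of the 4 values shown sit. The compounds shown leave open whether replacing methoxy with hydrogen changes toxicity, and at what concentration any of them becomes toxic.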